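Stretching a Hydroxy Chain by One Step

This account rests on a few compounds, and the source may have more. Where it says the series, first, only, none or still open, it means among the compounds named here.

In a functional assay on MCF7 cells (Homo sapiens) for antiproliferative activity, read by MTT assay, with a stated time of 24 h (a lower number here means a stronger inhibitor, a higher number a weaker inhibitor), compound 1 `CCn1c(C(=O)N[C@H](C)C(=O)OC)ccc1C(CC)(CC)c1ccc(OCS(=O)(=O)c2ccccc2)c(C)c1` gives > 50000 nM as a limit of the assay and not a number. Going by the values given here, compound 2 `CCn1c(C(=O)N[C@@H](CO)CCO)ccc1C(CC)(CC)c1ccc(OCS(=O)(=O)c2ccccc2)c(C)c1` gives 27400 nM as the only actual number so far. Compound 3 `CCn1c(C(=O)N[C@@H](CO)CCCO)ccc1C(CC)(CC)c1ccc(OCS(=O)(=O)c2ccccc2)c(C)c1` differs from compound 2 hydroxymethyl in place of hydroxy on a saturated chain carbon, three bonds along the chain from an amide-type nitrogen by having hydroxymethyl in place of hydroxy on a saturated chain carbon, three bonds along the chain from an amide-type nitrogen, so 2-hydroxyethyl becomes 3-hydroxypropyl. Among the compounds with values here, the one measured step of an at least 1.8-fold lower number from compound 1 to compound 2 (0.26 log units; that floor lies within the scatter) exchanged a different group on that nitrogen, so it offers no direct guide to this chain change. With nothing pointing either way, the expected step of a 1.1-fold lower number from compound 2 to compound 3 (0.02 log units; within the scatter) is none beyond the scatter in this assay and has no clear direction. The estimate for compound 3 is 26000 nM with an expected span from 12000 nM to 50000 nM around that figure.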

Compound 3, half-maximal inhibitory concentration: 29600 nM
Compound 3: the middle estimate sits 1.1-fold (0.06 log units) below what was measured; measured number inside the range.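

In this assay, the place three bonds along the chain from the amide-type nitrogen takes the extra carbon of 3-hydroxypropyl with no readable effect: the change gives a 1.1-fold higher number from compound 2 to compound 3 (0.03 log units; within the scatter), so compound 2 and compound 3 cannot be told apart here. Compound 1 gives > 50000 nM, which is a limit of the assay and not a number. The step to the longer chain is therefore only a floor, an at least 1.6-fold lower number from compound 1 to compound 3 (0.22 log units; that floor lies within the scatter), and it does not separate the two compounds: the limit of > 50000 nM in this assay, at which 1 of the 3 values shown sits.

Both hydroxy chains shown leave the values within the scatter of each other, so it remains open whether this position responds to any change at all. An amine or a carboxylic acid in place of the hydroxy, or a longer chain, would test that.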